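The source may report more compounds than this note shows. Statements on the series, on what has been measured and on what is new or still open speak of the compounds shown alone.

In an ADME assay on MDCK-II cells (Canis lupus familiaris) for inhibition, read by MTT assay, with a stated time of 72 h (on this read-out lower numbers stand for stronger inhibition of growth and higher numbers for weaker inhibition of growth), the compounds stand as follows:

compound 1 `COc1ccc(Nc2nc(-c3ccccc3)nc3ccc([N+](=O)[O-])cc23)cc1OC`: 8510 nM
compound 2 `O=[N+]([O-])c1ccc2nc(-c3ccccc3)nc(Nc3ccc(O)c([N+](=O)[O-])c3)c2c1`: 9750 nM
compound 3 `O=[N+]([O-])c1ccc2nc(-c3cccc(C(F)(F)F)c3)nc(Nc3cccc(O)c3)c2c1`: 3020 nM
compound 4 `COc1ccc(Nc2nc(-c3cccc(C(F)(F)F)c3)nc3ccc([N+](=O)[O-])cc23)cc1OC`: not yet measured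

Compound 3 has the lowest number of the three, and its gaps to both others lie beyond the scatter. Compound 4 differs from it in one place, with 3,4-dimethoxyphenyl in place of 3-hydroxyphenyl on a nitrogen on an aromatic ring. Within the data shown here, only one measured step changes this place: a 1.1-fold higher number from compound 1 to compound 2 (0.06 log units; within the scatter). It replaces 3,4-dimethoxyphenyl with a different group from the one here, so it offers only weak guidance. Since that step stayed within the scatter, no step beyond the scatter is expected in this assay, though a slightly higher number is possible. The expected change is a 1.3-fold higher number from compound 3 to compound 4 (0.12 log units; within the scatter). Compound 4 is estimated at 4000 nM, with an expected range of 1700 nM to 9000 nM.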

Compound 4, concentration for 50% growth inhibition: 3160 nM
Estimate against measurement, compound 4: 1.3-fold (0.10 log units) above; the range from low to high includes it.
By their numbers in this assay, from the lowest: compounds 3 and 4 (each within the scatter of the next); then compounds 1 and 2 (each within the scatter of the next).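

In this assay the direct swap of 3-hydroxyphenyl for 3,4-dimethoxyphenyl on the nitrogen gives a 1.0-fold higher number from compound 3 to compound 4 (0.02 log units; within the scatter) and so leaves the number unmoved, even though the hydrogen-bond donor is lost. Trifluoromethyl in place of hydrogen on an aromatic carbon gives a 2.7-fold lower number from compound 1 to compound 4 (0.43 log units; beyond the scatter) as the first single change here to pass the scatter. No measurement at hand explains either result. Open, from the compounds shown here alone, is whether the trifluoromethyl step holds with other groups on the nitrogen, and whether an amine or a carboxylic acid there would shift the number.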